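Swapping a dimethylphenyl for an iodophenyl on a ring nitrogen

The source may report more compounds than this note shows. Statements on the series, on what has been measured and on what is new or still open speak of the compounds shown alone.

Among the measured compounds shown here, in a functional assay on PC-3 cells (Homo sapiens) for inhibition, read by MTT assay, with a stated time of 72 h (a lower number here means a stronger inhibitor, a higher number a weaker inhibitor), compound 1 `Cc1ccc(-n2cc(CNC(=O)c3cccc4c3cnn4C(C)C)nn2)cc1C` gives 23400 nM, and compound 2 `Cc1ccc(-n2cc(CNC(=O)c3cccc4c3cnn4C(C)C)nn2)c(C)c1` gives 10600 nM, the lowest of the two numbers; the one measured step is a 2.2-fold lower number from compound 1 to compound 2 (0.34 log units; beyond the scatter). Compound 3 `CC(C)n1ncc2c(C(=O)NCc3cn(-c4ccc(I)cc4)nn3)cccc21` differs from compound 2 by 4-iodophenyl in place of 2,4-dimethylphenyl on an aromatic nitrogen. For the measured compounds named here, that single step concerns only 2,4-dimethylphenyl against 3,4-dimethylphenyl and does not cover 4-iodophenyl, so no measured step bears directly on this change. For compound 3 a number close to that of compound 2 is therefore expected, with no step beyond the scatter, a 1.2-fold lower number from compound 2 to compound 3 (0.07 log units; within the scatter). Compound 3 is estimated at 9000 nM, in a range from 3000 nM to 30000 nM.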

Compound 3, half-maximal inhibitory concentration: > 40000 nM
Compound 3 ended at the assay's limit; the forecaster's own chance of this, stated with the estimate: 10%; middle value at least 4.4-fold (0.64 log units) away from the limit.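

In this assay compound 3 stands at a limit and not at a number: the limit of > 40000 nM in this assay, at which 1 of the 3 values shown sits. Replacing 2,4-dimethylphenyl with 4-iodophenyl on the aromatic nitrogen gives an at least 3.7-fold higher number from compound 2 to compound 3 (0.57 log units; beyond the scatter), so this position tolerates less change than the dimethylphenyl pair alone showed. Replacing 3,4-dimethylphenyl gives an at least 1.7-fold higher number from compound 1 to compound 3 (0.23 log units; that floor lies within the scatter), and that floor does not separate compound 3 from compound 1.

On these data alone, whether the iodine or the loss of both methyl groups matters more stays open. So does how a 4-methylphenyl, 4-chlorophenyl or 4-aminophenyl group would read on this nitrogen.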